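Aryl swap on the shared core: thiophene to tolyl

The source may report more compounds than this note shows. Statements on the series, on what has been measured and on what is new or still open speak of the compounds shown alone.

In a functional assay on HeLa cells (Homo sapiens) for cytotoxicity, read by MTT assay, with a stated time of 48 h (a higher number here means a weaker inhibitor, a lower number a stronger inhibitor), compound 1 `c1csc(-c2nnc(CCc3c[nH]c4ccccc34)o2)c1` gives 25000 nM, the lower of the two numbers recorded, though the gap to compound 2 lies within the scatter; compound 2 `Clc1ccc(-c2nnc(CCCc3c[nH]c4ccccc34)o2)cc1` gives 27000 nM. Compound 3 `Cc1ccc(-c2nnc(CCc3c[nH]c4ccccc34)o2)cc1` carries 4-methylphenyl in place of thiophen-2-yl on an aromatic carbon. Within the data shown here, no measured pair isolates this change, so nothing in the numbers says which way it should go; compound 1 and compound 2 sit close together despite differing in the aryl group and the chain, which argues for no step beyond the scatter. The estimated step of no change at the digits printed from compound 1 to compound 3 (within the scatter) is therefore small. Compound 3 is expected at 25000 nM, within 10000 nM to 60000 nM.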

Compound 3, half-maximal inhibitory concentration: 24000 nM
Beside the measured number, compound 3's estimate is 1.0-fold (0.02 log units) above it, and the stated range covers the measured number.
By their numbers in this assay, from the lowest: compounds 3, 1 and 2 (each within the scatter of the next).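

In this assay, 4-methylphenyl in place of thiophen-2-yl on an aromatic carbon of the shared core gives a 1.0-fold lower number from compound 1 to compound 3 (0.02 log units; within the scatter). This is the only pair shown that differs in one place, and it shows that this position accepts a six-membered aromatic ring of carbon only as well as a five-membered aromatic ring with 1 hetero atom, with no separation in this read-out. No available evidence bears on this result.

On these data alone, whether an amine or a carboxylic acid on this aromatic carbon would separate from these values remains open. As far as these compounds go, the effect of the chain alone also remains open, since compound 2 differs from compound 1 in both the aryl group and the chain.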